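One double bond redrawn, and what it may change

The source may report more compounds than this note shows. Statements on the series, on what has been measured and on what is new or still open speak of the compounds shown alone.

Compound 1 `Cc1ccc(/C=C\c2ccc3ccccc3c2)cc1` gives > 5000 nM (a limit)
Compound 2 `FC(F)(F)c1ccc(/C=C\c2ccc3ccccc3c2)cc1` gives > 5000 nM (a limit)
Compound 3 `CN(C)c1ccc(/C=C/c2ccc3ccccc3c2)cc1` gives 3660 nM (a number)

Only compound 3 has a true number in a functional assay on SK-MEL-28 cells (Homo sapiens) for inhibition (on this read-out higher numbers stand for weaker inhibition and lower numbers for stronger inhibition), so far, with 3660 nM as its value. Compound 1 and compound 2 stand at the limit of > 5000 nM in this assay, at which 2 of the 3 values shown sit, and offer a limit only. Compound 4 `CN(C)c1ccc(/C=C\c2ccc3ccccc3c2)cc1` differs from compound 3 through the two compounds have the same atoms and bonds and differ only in configuration as drawn: 1 of 1 stereo elements differ; a double bond is drawn E in compound 3 and Z in compound 4 and nothing else. The double bond is drawn E in compound 3 and Z in compound 4. Among the compounds with values here, the single measured step, a step that the two limits leave unreadable from compound 1 to compound 2, involves no such change and gives no size to borrow. Compound 1 and compound 2 are also drawn Z, which gives only a weak hint. No clear shift is therefore expected, and the expected move is a 1.1-fold higher number from compound 3 to compound 4 (0.04 log units; within the scatter). The anchor is compound 3 at 3660 nM. Compound 4 is estimated at 4000 nM, with a range from 1200 nM to 10000 nM.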

Compound 4, half-maximal inhibitory concentration: 3660 nM
The estimate for compound 4 lay 1.1-fold (0.04 log units) above the measured number, within the range that was stated.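

In this assay the result is no change at the digits printed from compound 3 to compound 4 (within the scatter), and the comparison is a clean one: the fact that compounds 3 and 4 differ only in the configuration as drawn. With the double bond drawn Z in all three compounds, the change of group gives an at least 1.3-fold lower number from compound 2 to compound 4 (0.13 log units; that floor lies within the scatter) and an at least 1.3-fold lower number from compound 1 to compound 4 (0.13 log units; that floor lies within the scatter). Both of these steps start from a limit, not a true number: the limit of > 5000 nM in this assay, at which 2 of the 4 values shown sit.

On these data alone, it remains open whether a primary amine or a carboxylic acid in place of dimethylamino would move the number beyond the scatter. As far as these compounds go, whether redrawing the double bond matters with methyl or trifluoromethyl in that place also remains open.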